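This account rests on a few compounds, and the source may have more. Where it says the series, first, only, none or still open, it means among the compounds named here.

Three compounds built on a shared core have been run in a functional assay, with a stated time of 6 min; on this read-out higher numbers stand for weaker inhibition and lower numbers for stronger inhibition. Compound 1 `CCOc1ccccc1NCn1nc(-c2ccc3c(c2)OCCO3)oc1=S` gives 5280 nM in this assay. Compound 2 `S=c1oc(-c2ccc3c(c2)OCCO3)nn1CNc1ccc(Cl)cc1` gives 7270 nM. Compound 3 `S=c1oc(-c2ccc3c(c2)OCCO3)nn1CNc1cc(Cl)ccc1Cl` gives 5420 nM. Compound 3 therefore holds the second highest of the three numbers; its nearest neighbour is compound 1 and its furthest is compound 2, and both gaps stay within the scatter: a 1.0-fold higher number from compound 1 to compound 3 (0.01 log units; within the scatter) and a 1.3-fold lower number from compound 2 to compound 3 (0.13 log units; within the scatter).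

Compound 4 `COc1ccccc1NCn1nc(-c2ccc3c(c2)OCCO3)oc1=S` differs from compound 3 in one place: 2-methoxyphenyl in place of 2,5-dichlorophenyl on an amine nitrogen. The measured steps that touch this position are a 1.4-fold higher number from compound 1 to compound 2 (0.14 log units; within the scatter), a 1.0-fold higher number from compound 1 to compound 3 (0.01 log units; within the scatter) and a 1.3-fold lower number from compound 2 to compound 3 (0.13 log units; within the scatter), every one of them within the scatter. No step beyond the scatter is expected from compound 3 to compound 4 in this assay, because compound 1 carries 2-ethoxyphenyl on the amine nitrogen and a 1.0-fold higher number from compound 1 to compound 3 (0.01 log units; within the scatter) stays within the scatter, so the expected step is a 1.0-fold lower number from compound 3 to compound 4 (0.00 log units; within the scatter). Compound 4 is estimated at 5400 nM, with a range from 2700 nM to 10800 nM.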

Compound 4, half-maximal inhibitory concentration: 6300 nM
The estimate for compound 4 lay 1.2-fold (0.07 log units) below the measured number, and the stated range covers the measured number.
By their numbers in this assay, from the lowest: compounds 1, 3, 4 and 2 (each within the scatter of the next).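

In this assay, 2-methoxyphenyl on the amine nitrogen stays within the scatter of both chlorinated groups, whether it replaces 2,5-dichlorophenyl (a 1.2-fold higher number from compound 3 to compound 4 (0.07 log units; within the scatter)) or 4-chlorophenyl (a 1.2-fold lower number from compound 2 to compound 4 (0.06 log units; within the scatter)), even though it brings a hydrogen-bond acceptor and no chlorine. The first change made on the alkoxy group itself, hydrogen in place of methyl on a saturated chain carbon bound to an oxygen on an aromatic ring, also stays within the scatter (a 1.2-fold higher number from compound 1 to compound 4 (0.08 log units; within the scatter)). No available evidence accounts for these small steps.

All four aryl groups shown are substituted phenyl rings, so it remains open whether a carboxylic acid or an amine on that ring would shift the number beyond the scatter. The same question stands for a longer chain on the oxygen, or for a saturated ring in place of the phenyl.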